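The source may report more compounds than this note shows. Statements on the series, on what has been measured and on what is new or still open speak of the compounds shown alone.

Measured compounds in a functional assay on cells (Tumor Cell line, Homo sapiens) for cytotoxicity; a lower number here means a stronger inhibitor, a higher number a weaker inhibitor:
compound 1, `CN(C)Cc1cc(C(=O)/C=C/c2ccccc2Cl)cc(CN(C)C)c1O`, 9550 nM
compound 2, `CN(C)Cc1cc(C(=O)/C=C/c2cccc(Cl)c2)cc(CN(C)C)c1O`, 4680 nM

Compound 2 stands lowest of the two numbers; the nearest is compound 1 at 9550 nM, and the step of a 2.0-fold lower number from compound 1 to compound 2 (0.31 log units; beyond the scatter) is modest but beyond the scatter. Compound 3, `CN(C)Cc1cc(C(=O)/C=C/c2c(Cl)cccc2Cl)cc(CN(C)C)c1O`, is the next compound to be measured in this assay. It differs from compound 2 in one place: 2,6-dichlorophenyl in place of 3-chlorophenyl on a double-bonded chain carbon bound to a double-bonded chain carbon.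

For the measured compounds named here, only one measured step bears on this change. The step of a 2.0-fold lower number from compound 1 to compound 2 (0.31 log units; beyond the scatter) shows that moving the single chlorine from the 2-chlorophenyl of compound 1 to the 3-chlorophenyl of compound 2 lowered the number modestly. Going by the values given here, compound 3 brings back the 2-chlorophenyl pattern of compound 1 and adds a second chlorine in the 2,6-dichlorophenyl; no measured pair shows what the second chlorine does. Compound 3 is therefore expected to give a higher number than compound 2, with the expected step of a 1.9-fold higher number from compound 2 to compound 3 (0.28 log units; within the scatter) roughly undoing the gain seen in compound 2. The estimate for compound 3 is 9000 nM, within a range of 3500 nM to 25000 nM.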

Compound 3, half-maximal inhibitory concentration: 5880 nM
The estimate for compound 3 lay 1.5-fold (0.18 log units) above the measured number; low and high end bracket the measured number.
By their numbers in this assay, from the lowest: compounds 2, 3 and 1 (each within the scatter of the next, the first and the last beyond it).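

In this assay, for the compounds shown here, the step for adding a chlorine to the ring of compound 1 is the first reading of what a second chlorine does (a 1.6-fold lower number from compound 1 to compound 3 (0.21 log units; within the scatter)), and it leaves the 2,6-dichlorophenyl of compound 3 indistinguishable from the 2-chlorophenyl of compound 1. Going by these compounds alone, the exchange at the same place for the 3-chlorophenyl is also within the scatter (a 1.3-fold higher number from compound 2 to compound 3 (0.10 log units; within the scatter)), so compound 3 cannot be separated from compound 2 either, and the only step among the three compounds that lies beyond the scatter remains the one between the two single-chlorine compounds (a 2.0-fold lower number from compound 1 to compound 2 (0.31 log units; beyond the scatter)). The series therefore shows that this place on the chain tolerates the 2,6-dichlorophenyl without a readable change in either direction, though nothing measured gives a reason for these numbers.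

The compounds shown leave open how this place responds to a substituent other than chlorine, such as a methoxy group, a nitrile or a carboxylic acid on the phenyl ring. They also leave open whether a group larger than chlorine would produce a step beyond the scatter from compound 3.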